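Urea series: cytotoxicity limits and a methoxy replacement

A few compounds are considered here, and "the series" means these few. Any claim that something is new, unique, unknown or untested is made for them only; others in the source may bear on it.

Measured compounds:
compound 1, `Cc1cc(NC(=O)Nc2ccc(N(C)C)cc2)c2ccccc2n1`: > 25000 nM
compound 2, `Cc1cc(NC(=O)Nc2cccc3nsnc23)c2ccccc2n1`: > 25000 nM
compound 3, `COc1cccc(NC(=O)Nc2cc(C)nc3ccccc23)c1`: > 25000 nM

In an ADME assay on HEK293 cells (Homo sapiens) for cytotoxicity, with a stated time of 72 h (a lower number here means that less compound is needed, a higher number that more compound is needed for the effect), compound 1 gives > 25000 nM, which is a limit of the assay and not a number. Compound 2 likewise returns only a limit, > 25000 nM. Compound 3 also stands at a limit, > 25000 nM. Within the data shown here, all three results sit at the same point, (the limit of > 25000 nM in this assay, at which 3 of the 3 values shown sit), so compound 1 cannot be placed above or below compound 2 or compound 3 on this read-out, and no step between measured compounds can be sized.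

Compound 4, `COc1ccc(NC(=O)Nc2cc(C)nc3ccccc23)cc1`, is not yet measured. It differs from compound 1 by methoxy in place of dimethylamino on an aromatic carbon. The shared core and the urea link are untouched. With every measured value at the limit, the step from compound 1 to compound 4 in this assay is expected to be none beyond the scatter, a step that the limit leaves unreadable from compound 1 to compound 4. Compound 4 is expected to give 30000 nM, between 15000 nM and 60000 nM, most likely again reported only as a limit.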

Compound 4, half-maximal effective concentration: > 25000 nM
Compound 4 ended at the assay's limit; the forecaster's own chance of this, stated with the estimate: 85%; the middle value is on the limit's open side.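

No step can be read between compound 1 and compound 4 in this assay, because both results are limits and not numbers: the limit of > 25000 nM in this assay, at which 4 of the 4 values shown sit.

The compounds shown leave open at what concentration any of them is cytotoxic, and whether methoxy in place of dimethylamino alters that concentration.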